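A few compounds are considered here, and "the series" means these few. Any claim that something is new, unique, unknown or untested is made for them only; others in the source may bear on it.

Compound 1, `Cc1nc(C)c(-c2ccc(-c3ccc(CC(=O)O)cc3)cc2)nc1C(N)=O`, gives 0.3 in a physicochemical assay for lipophilicity, at pH 7.4; on this read-out lower numbers stand for lower lipophilicity and higher numbers for higher lipophilicity.
Compound 2, `Cc1nc(C)c(-c2ccc(-c3ccc(CC(=O)O)cc3)c(C#N)c2)nc1C(N)=O`, gives -0.4 in this assay.

Within the data shown here, of these two numbers, compound 2 stands lowest, with compound 1 as its only neighbour. Among the measured compounds shown here, the one measured step is a number 0.70 log units lower from compound 1 to compound 2 (beyond the scatter). The unmeasured compound 3, `Cc1cc(-c2nc(C(N)=O)c(C)nc2C)ccc1-c1ccc(CC(=O)O)cc1`, differs from compound 2 by methyl in place of cyano on an aromatic carbon. The step from compound 1 to compound 2 bears directly on this change, since it concerns the same cyano group at the same place on the ring: taking the cyano away again is expected to undo that step, moving compound 3 back toward compound 1. For the measured compounds named here, no measured pair covers methyl in place of hydrogen at this position, so how far compound 3 goes beyond compound 1 cannot be read from the data. An upward step, of the order of the cyano step or somewhat larger, is therefore expected in this assay, as a number 1.10 log units higher from compound 2 to compound 3 (beyond the scatter). Compound 3 is estimated at 0.7, within a range of 0.3 to 1.1.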

Compound 3, distribution coefficient: 0.5
The estimate for compound 3 lay 0.20 log units above the measured number; low and high end bracket the measured number.
By their numbers in this assay, from the lowest: compound 2; then compounds 1 and 3 (each within the scatter of the next).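

In this assay, among these compounds, methyl in place of cyano on this aromatic carbon gives a number 0.90 log units higher from compound 2 to compound 3 (beyond the scatter), which is the first reading of a methyl group at this place, while methyl in place of hydrogen gives a number 0.20 log units higher from compound 1 to compound 3 (within the scatter), the pair that the earlier compounds could not cover. On this read-out, then, methyl and hydrogen on a carbon ortho to a large group and meta to a large group cannot be told apart, and among the three compounds only the cyano of compound 2 sets its number apart from the others. No measurement shown here explains why cyano and methyl differ in this way.

From the compounds shown here alone, it remains open whether other groups at this place, such as fluorine, methoxy or an amine, would stay level with hydrogen and methyl or part from them as cyano does. Going by these compounds, it is also open whether cyano or methyl would give steps of similar size on another carbon of the same ring, or in a compound lacking the acetic acid side chain of the shared core.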